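Replacing an aryl hydrazide by a diacyl hydrazide

A few compounds are considered here, and "the series" means these few. Any claim that something is new, unique, unknown or untested is made for them only; others in the source may bear on it.

Measured so far:
compound 1 `O=C(NNc1ccc(F)cc1)c1ccc(NS(=O)(=O)c2cnc(O)nc2O)cc1`: > 20000 nM
compound 2 `O=C(NNc1cccc(Cl)c1)c1cccc(NS(=O)(=O)c2cnc(O)nc2O)c1`: 8040 nM
compound 3 `Cc1ccccc1NNC(=O)c1ccccc1NS(=O)(=O)c1cnc(O)nc1O`: > 20000 nM

Of the compounds shown here, three sharing a sulfonamide-linked core have been tested in a functional assay on OVCAR-3 cells (Homo sapiens) for antiproliferative activity, read by MTT assay, with a stated time of 24 h; on this read-out lower numbers stand for stronger inhibition and higher numbers for weaker inhibition. Compound 2 is the only one with a numerical result, giving 8040 nM. For compound 1 the result is a limit of the assay, > 20000 nM, and not a number. For compound 3 the result is likewise a limit, > 20000 nM, so compound 3 stands at the edge of what the assay can report, a position it shares with one other compound (the limit of > 20000 nM in this assay, at which 2 of the 3 values shown sit).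

Compound 4 `O=C(NNC(=O)c1ccccc1NS(=O)(=O)c1cnc(O)nc1O)c1cccc(Cl)c1` is not yet measured. It differs from compound 3 in one place: (3-chlorophenyl)carbonyl in place of 2-methylphenyl on an amine nitrogen. Among the compounds with values here, since no step between two measured compounds is known, the size of this change can only be guessed. Given that compound 3 sits at the limit, the expectation for compound 4 is a small shift at most, with the direction unknown and most likely a result that remains near or at the limit in this assay. The expected step of an at least 1.1-fold lower number from compound 3 to compound 4 (0.04 log units; that floor lies within the scatter) is modest. Compound 4 is therefore estimated at 18000 nM, within 6000 nM to 50000 nM.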

Compound 4, half-maximal inhibitory concentration: 2080 nM
Compound 4: middle estimate off by 8.7-fold (0.94 log units), on the high side, outside the stated range (below it).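

In this assay, the amine nitrogen of the hydrazide proves to be a place where a single change can matter: (3-chlorophenyl)carbonyl in place of 2-methylphenyl, which turns the aryl hydrazide into a diacyl hydrazide, gives an at least 9.6-fold lower number from compound 3 to compound 4 (0.98 log units; beyond the scatter). Within the data shown here, this is the first size available for any change, as the earlier compounds offered no pair differing in one place. Its true size stays unknown because the starting compound gives no number, only the limit that compound 3 shares with one other compound: the limit of > 20000 nM in this assay, at which 2 of the 4 values shown sit.

The change swaps the whole group, adding a carbonyl and exchanging the methyl-bearing ring for a chlorine-bearing one, so the compounds shown cannot tell which of these parts accounts for the lower number. A plain benzoyl group or (2-methylphenyl)carbonyl on that nitrogen would separate the two parts, and an acetyl group would test whether an aromatic ring is needed there at all.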